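The source may hold more compounds than are shown below. What is called first, only, known or untested is meant among the compounds shown, and "the series" means these compounds.

Compound 1 `C=C(C)[C@@H]1CC=C(Cn2cc(COc3ccc(C4NC(=O)NC(C)=C4C(C)=O)cc3)nn2)CC1` and compound 2 `C=C(C)[C@@H]1CC=C(Cn2cc(COc3ccc(C4NC(=O)NC(C)=C4C(C)=O)cc3OC)nn2)CC1` share one core, while compound 3 `C=C(C)[C@@H]1CC=C(Cn2cc(COc3cccc(C4NC(=O)NC5=C4C(=O)CC(C)(C)C5)c3)nn2)CC1` and compound 4 `C=C(C)[C@@H]1CC=C(Cn2cc(COc3cc(C4NC(=O)NC5=C4C(=O)CC(C)(C)C5)ccc3OC)nn2)CC1` share another; the difference between the two cores is not broken down here. In a functional assay on MCF7 cells (Homo sapiens) for inhibition, read by sulforhodamine B assay, with a stated time of 48 h (on this read-out higher numbers stand for weaker inhibition of growth and lower numbers for stronger inhibition of growth), compound 1 gives 29000 nM, and compound 2 gives 53300 nM. Compound 2 carries methoxy in place of hydrogen on an aromatic carbon, and that change made a 1.8-fold higher number from compound 1 to compound 2 (0.26 log units; within the scatter). In this assay compound 3 gives 31000 nM. Compound 4 carries methoxy in place of hydrogen on an aromatic carbon, the same kind of change, though here the new group stands para to a large group, where in compound 2 it stood meta to a large group. Because compound 3 gives 31000 nM and the same change made a 1.8-fold higher number from compound 1 to compound 2 (0.26 log units; within the scatter), the expected step is a 1.6-fold higher number from compound 3 to compound 4 (0.21 log units; within the scatter). Compound 4 is therefore estimated at 50000 nM in this assay, with a likely range from 25000 nM to 110000 nM.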

Compound 4, concentration for total growth inhibition: 44800 nM
Beside the measured number, compound 4's estimate is 1.1-fold (0.05 log units) above it; low and high end bracket the measured number.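

In this assay, methoxy in place of hydrogen on an aromatic carbon gives a 1.4-fold higher number from compound 3 to compound 4 (0.16 log units; within the scatter), so on this core too the step stays within the scatter. Set beside the earlier step, the change looks alike on both cores: the same change on two cores in this assay, a 1.8-fold higher number (0.26 log units; within the scatter) from compound 1 to compound 2 and a 1.4-fold higher number (0.16 log units; within the scatter) from compound 3 to compound 4, 1.3-fold (0.10 log units) apart, within the scatter of two such steps. This shows that a small step carried over from one core to the other in these two pairs, but with both steps within the scatter, it does not show that methoxy truly alters growth inhibition on either core.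

On these data alone, it remains open whether a different group in the same place, such as an amine, a carboxylic acid or a longer chain, would give a step beyond the scatter. As far as these compounds go, whether methoxy would behave the same way on a third core also remains open.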